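The source may hold more compounds than are shown below. What is called first, only, known or untested is meant among the compounds shown, and "the series" means these compounds.

Of the compounds shown here, three have been tested in an ADME assay on J744 cells (Mus musculus) for cytotoxicity, read by MTT assay, with a stated time of 48 h (on this read-out lower numbers stand for stronger inhibition and higher numbers for weaker inhibition), and each result is a limit, not a number. Compound 1 `Cc1c(C(=O)N/N=C/c2ccco2)no[n+]1[O-]` stands at a limit of > 400000 nM. Compound 2 `COc1cc(/C=N/NC(=O)c2no[n+]([O-])c2C)ccc1O` stands at a limit of > 400000 nM. Compound 3 `O=C(O)c1ccc(/C=N/NC(=O)c2c(-c3ccccc3)no[n+]2[O-])cc1` stands at a limit of > 300000 nM. Compound 1 therefore shares its limit with compound 2, and no ranking of the three can be read from these results.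

Compound 4 `Cc1c(C(=O)N/N=C/c2cccs2)no[n+]1[O-]` has not yet been measured in this assay. It differs from compound 1 by a single swap, thiophen-2-yl in place of furan-2-yl on a carbon with a double bond to nitrogen. Going by the values given here, no measured pair shows what this swap does, so no step beyond the usual scatter is expected in either direction. That expectation starts from compound 1, with its limit of > 400000 nM. The estimated change is a number no higher from compound 1 to compound 4 (the limit leaves the size open). Compound 4 is estimated at 400000 nM, with an expected range from 200000 nM to 800000 nM.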

Compound 4, half-maximal inhibitory concentration: > 400000 nM
Compound 4: a limit, no number; the forecaster's own chance of this, stated with the estimate: 75%; the middle value lies on the limit itself.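

Compound 1 and compound 4 both give limits rather than numbers, so the step from furan-2-yl to thiophen-2-yl on the shared core cannot be read. The compounds shown leave open whether this swap changes cytotoxicity at all, because most results rest on one ceiling: the limit of > 400000 nM in this assay, at which 3 of the 4 values shown sit.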